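The source may hold more compounds than are shown below. What is called first, only, known or untested is meant among the compounds shown, and "the series" means these compounds.

Compound 2 `O=C(O)c1ccc(C(=O)/C=C/c2ccc3c(c2)B(O)OC3)cc1` stands only at a limit in an ADME assay on L929 cells (Mus musculus) for cytotoxicity, read by resazurin assay, with a stated time of 72 h; a higher number here means a weaker inhibitor, a lower number a stronger inhibitor: compound 2 gives > 10 ug/mL, which is a limit of the assay and not a number. Compound 3 `O=C(/C=C/c1ccc2c(c1)B(O)OC2)c1ccc(Cl)cc1` carries chloro in place of carboxy on an aromatic carbon, para to a large group (chloro in place of carboxy on an aromatic carbon). Going by the values given here, no measured pair shows this change alone. Compound 1 `Cc1cccc(C(=O)/C=C/c2ccc3c(c2)B(O)OC3)c1`, which also has no carboxy, gives 8.56 ug/mL in this assay, and that value anchors the expectation. A modest step towards a stronger inhibitor is expected, an at least 1.6-fold lower number from compound 2 to compound 3 (0.22 log units; that floor lies within the scatter). The estimated value for compound 3 is 6 ug/mL, with an expected range of 2 ug/mL to 15 ug/mL.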

Compound 3, half-maximal inhibitory concentration: > 10 ug/mL
Compound 3 was reported as a limit (the forecaster's own chance of this, stated with the estimate: 25%); at least 1.6-fold (0.22 log units) between middle value and limit.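

In this assay compound 3 gives > 10 ug/mL, which is a limit and not a number. The step for chloro in place of carboxy cannot be read because both compounds sit at the same limit: the limit of > 10 ug/mL in this assay, at which 2 of the 3 values shown sit. Going by these compounds alone, the one step that can be read, for 4-chlorophenyl in place of 3-methylphenyl on a carbonyl carbon, is an at least 1.1-fold higher number from compound 1 to compound 3 (0.06 log units; that floor lies within the scatter), so no firm change can be claimed. On these data alone, what an amine or a methoxy group would give at this place remains open. So does whether any group here gives a clear separation from compound 1.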